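Aryl variation on the ring amine nitrogen, cell growth assay

This account rests on a few compounds, and the source may have more. Where it says the series, first, only, none or still open, it means among the compounds named here.

Measured so far:
compound 1 `Cc1ccc(N2CCN(C(=S)N/N=C3\C(=O)Nc4ccc(Cl)cc43)CC2)cc1` — in a functional assay on HCT-116 cells (Homo sapiens) for inhibition, read by MTT assay, with a stated time of 72 h (a lower number here means a stronger inhibitor, a higher number a weaker inhibitor), compound 1 gives 6390 nM
compound 2 `O=C1Nc2ccc(Cl)cc2/C1=N/NC(=S)N1CCN(c2ccccc2Cl)CC1` — in this assay compound 2 gives 4910 nM

Compound 2 holds the lowest of the two numbers, but the step of a 1.3-fold lower number from compound 1 to compound 2 (0.11 log units; within the scatter) is within the scatter, so the two compounds are not separated by these data; they sit together in the micromolar region.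

Compound 3 `O=C1Nc2ccc(Cl)cc2/C1=N/NC(=S)N1CCN(c2ccc([N+](=O)[O-])cc2)CC1` keeps the shared core and the thiosemicarbazide-linked ring, and differs from compound 2 only in the aryl group on the ring nitrogen: 4-nitrophenyl in place of 2-chlorophenyl on an amine nitrogen in a ring.

Within the data shown here, the one measured step that bears on this change is a 1.3-fold lower number from compound 1 to compound 2 (0.11 log units; within the scatter), which also swaps the aryl group on the same ring nitrogen and stays within the scatter. With a single such comparison there is no basis for expecting the exchange for the 4-nitrophenyl group to move the number beyond the scatter in either direction. The expected step is therefore a 1.0-fold higher number from compound 2 to compound 3 (0.01 log units; within the scatter), essentially flat.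

Compound 3 is estimated at 5000 nM in this assay, with a range of 2000 nM to 12500 nM to cover the uncertainty of a change not yet sampled.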

Compound 3, half-maximal inhibitory concentration: 12000 nM
Estimate against measurement, compound 3: 2.4-fold (0.38 log units) below; the measured number falls inside the stated range.
By their numbers in this assay, from the lowest: compounds 2, 1 and 3 (each within the scatter of the next, the first and the last beyond it).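

In this assay, the aryl group on the ring amine nitrogen now gives a step that clears the scatter, a 2.4-fold higher number from compound 2 to compound 3 (0.39 log units; beyond the scatter), a modest one and the only separation among the compounds shown. The 4-nitrophenyl group of compound 3 is not separated from the 4-methylphenyl group of compound 1, with a 1.9-fold higher number from compound 1 to compound 3 (0.27 log units; within the scatter), so compound 1 cannot be set apart from either of the other two, and only the two ends of this small set are resolved. Nothing measured here offers an explanation for the step from the 2-chlorophenyl group to the 4-nitrophenyl group.

Compound 2 and compound 3 differ both in the substituent and in where it sits on the phenyl ring, so these data cannot assign the step to either, and a 4-chlorophenyl group would help to separate the two. On these data alone, it also remains open whether an aryl group is needed on this nitrogen at all, and whether a benzyl or acetyl group there, or an amine or carboxylic acid on the phenyl ring, would move the number beyond the scatter in either direction.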